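This account rests on a few compounds, and the source may have more. Where it says the series, first, only, none or still open, it means among the compounds named here.

Measured in an ADME assay on HPLF cells (Homo sapiens) for cytotoxicity, with a stated time of 24 h; on this read-out higher numbers stand for lower toxicity in this test and lower numbers for higher toxicity in this test:
Compound 1 `O=C1/C(=C/c2ccccc2)CCC/C1=C\c1ccc([N+](=O)[O-])cc1`: 282000 nM
Compound 2 `O=C1/C(=C/c2ccc(Cl)cc2)CCC/C1=C\c1ccc([N+](=O)[O-])cc1`: 332000 nM

Compound 2, at 332000 nM, stands level with compound 1 within the scatter. Compound 3 `Cc1ccc(/C=C2\CCC/C(=C\c3ccc([N+](=O)[O-])cc3)C2=O)cc1` has methyl in place of chloro on an aromatic carbon, a change from 4-chlorophenyl to 4-methylphenyl. Within the data shown here, the one measured step bearing on it is a 1.2-fold higher number from compound 1 to compound 2 (0.07 log units; within the scatter), which exchanged hydrogen for chloro at that place and stayed within the scatter. No step beyond the scatter is therefore expected. The estimate means a 1.1-fold lower number from compound 2 to compound 3 (0.04 log units; within the scatter), an expected step within the scatter. For compound 3 the expected value is 300000 nM, with an estimated range of 150000 nM to 600000 nM.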

Compound 3, half-maximal cytotoxic concentration: 348000 nM
Estimate against measurement, compound 3: 1.2-fold (0.06 log units) below; measured number inside the range.
By their numbers in this assay, from the lowest: compounds 1, 2 and 3 (each within the scatter of the next).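

In this assay the step of a 1.0-fold higher number from compound 2 to compound 3 (0.02 log units; within the scatter) and the step of a 1.2-fold higher number from compound 1 to compound 3 (0.09 log units; within the scatter) put methyl level with both chloro and hydrogen at this place. Where the earlier compounds offered a single pair, three groups on this aromatic carbon now lie within the scatter of one another. Nothing at hand explains why the number stays flat here. As far as these compounds go, whether an amine, a carboxylic acid or a longer chain at this place would carry the number beyond the scatter remains open.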